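Swapping the furan arm of compound 1 for a fluorophenyl

The compounds below may be only part of what the source reports. "The series", "measured", "known", "first", "only" and "open" are said of these compounds alone.

The study measures binding to Myc in an assay on cells for binding affinity to Myc proto-oncogene protein (Homo sapiens); a lower number here means a stronger inhibitor, a higher number a weaker inhibitor. Compound 1 (`N#Cc1ccc(-c2cc(-c3ccc(C(N)=O)cc3)cc(-c3ccco3)n2)cc1`) gives 3000 nM there. Compound 2 (`N#Cc1ccc(-c2cc(-c3ccc(-c4nnn[nH]4)cc3)cc(-c3ccco3)n2)cc1`) gives 2000 nM, and the step of a 1.5-fold lower number from compound 1 to compound 2 (0.18 log units; within the scatter) shows that the two numbers sit within the usual scatter of one another. Compound 3 (`N#Cc1ccc(-c2cc(-c3ccc(C(=O)NN)cc3)cc(-c3ccco3)n2)cc1`) gives only a limit of the assay, > 100000 nM, as noted in the limit of > 100000 nM in this assay, at which 1 of the 3 values shown sits. Relative to that limit, the steps of an at least 33-fold higher number from compound 1 to compound 3 (1.52 log units; beyond the scatter) and an at least 50-fold higher number from compound 2 to compound 3 (1.69 log units; beyond the scatter) are both large.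

Compound 4 (`N#Cc1ccc(-c2cc(-c3ccc(C(N)=O)cc3)cc(-c3cccc(F)c3)n2)cc1`) has not yet been measured. It differs from compound 1 in one place: 3-fluorophenyl in place of furan-2-yl on an aromatic carbon. All three measured steps alter the substituent on the 4-carbamoylphenyl group, not the arm next to the ring nitrogen of the shared core, so none of them bears directly on this change. Among the measured compounds shown here, the only guidance is that the carbamoyl group, which compound 4 keeps, gave a number in compound 1 rather than a limit. For the measured compounds named here, with no measured precedent for the arm itself, no step beyond the scatter is expected in this assay. For compound 4 the expected step is a 1.2-fold higher number from compound 1 to compound 4 (0.07 log units; within the scatter). Compound 4 is therefore estimated at 3500 nM, within a range from 1000 nM to 12000 nM.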

Compound 4, half-maximal inhibitory concentration: > 100000 nM
Compound 4 gave a limit, no number; the forecaster's own chance of this, stated with the estimate: 15%; at least 28-fold (1.45 log units) between middle value and limit.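

In this assay, the arm on the aromatic carbon next to the ring nitrogen turns out to matter: with the 4-carbamoylphenyl and 4-cyanophenyl groups left in place, putting 3-fluorophenyl where furan-2-yl stood gives an at least 33-fold higher number from compound 1 to compound 4 (1.52 log units; beyond the scatter). Among the compounds shown here, the earlier steps all changed the substituent on the other arm, so this is the first sign that the read-out also depends on this position, and that keeping the carbamoyl group does not by itself secure a number. The value of compound 4 is a limit of the assay and not a number, so the step shows only the least size of the loss, and the true gap stays unknown: the limit of > 100000 nM in this assay, at which 2 of the 4 values shown sit.

Going by these compounds, what remains open is which part of the exchange counts, the swap of the five-membered ring with its oxygen for a six-membered carbon ring or the fluorine itself. An unsubstituted phenyl or a thiophen-2-yl at this position would separate the two, and whether either keeps a number in this assay is still unanswered.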